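The source may report more compounds than this note shows. Statements on the series, on what has been measured and on what is new or still open speak of the compounds shown alone.

Among the compounds with values here, compound 1 `CCN(CC)S(=O)(=O)c1ccc(S(=O)(=O)N2CCC[C@@H](C(=O)NC3CN(C(=O)C4CC4)C3)C2)cc1` was tested in a functional assay on MIA PaCa-2 cells (Homo sapiens) for inhibition, read by MTT assay, with a stated time of 3 days (a lower number here means a stronger inhibitor, a higher number a weaker inhibitor), where compound 1 gives 3100 nM, the highest number among the three compounds measured so far. The nearest of the others is compound 3 `CCOC(=O)[C@@H]1C[C@H](O)CN(S(=O)(=O)c2ccc(S(=O)(=O)N(CC)CC)cc2)C1`, which in this assay gives 300 nM; the furthest is compound 2 `CCN(CC)S(=O)(=O)c1ccc(S(=O)(=O)N2CCC[C@@H](C(=O)N3CCC(c4nc(C(C)C)no4)CC3)C2)cc1`, which in this assay gives 30 nM. Both of these gaps lie beyond the usual scatter. Compound 4 `CCN(CC)S(=O)(=O)c1ccc(S(=O)(=O)N2CCC[C@@H](C(=O)NC3CN(C(=O)NC(C)(C)C)C3)C2)cc1` has not yet been measured. It differs from compound 1 in one place: (tert-butyl)amino in place of cyclopropyl on a carbonyl carbon. Within the data shown here, no measured pair here shows this change, so there is no step to lean on. The step of a 1.0-fold lower number from compound 1 to compound 4 (0.01 log units; within the scatter) is expected to be small, not clearly beyond the scatter in either direction. For compound 4 the estimate is 3000 nM, with a range from 900 nM to 10000 nM.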

Compound 4, half-maximal inhibitory concentration: 1400 nM
The estimate for compound 4 lay 2.1-fold (0.33 log units) above the measured number, and the stated range covers the measured number.
By their numbers in this assay, from the lowest: compound 2; then compound 3; then compound 4; then compound 1.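

The change from cyclopropyl to (tert-butyl)amino on this carbonyl carbon gives a 2.2-fold lower number from compound 1 to compound 4 (0.35 log units; beyond the scatter) in this assay as a modest gain. This position therefore accepts a larger, ring-free group carrying a hydrogen-bond donor without the number rising, although the result stays well short of the lowest number in the set. Nothing measured here explains why the number moved.

The ring loss, the added bulk and the new nitrogen all arrive together in this one change. A plain tert-butyl or a cyclopropylamino group on the same carbonyl carbon would help separate them.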